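The source may report more compounds than this note shows. Statements on the series, on what has been measured and on what is new or still open speak of the compounds shown alone.

In a functional assay on B16-F10 cells (Mus musculus) for antiproliferative activity, read by MTT assay, with a stated time of 48 h (on this read-out higher numbers stand for weaker inhibition and lower numbers for stronger inhibition), compound 2 (`Cc1ccc(NCc2cn(-c3ccccc3)nc2-c2ccc(C)cc2)cc1`) gives 7380 nM and stands level, within the scatter, with its two measured neighbours: compound 1 (`COc1ccc(-c2nn(-c3ccccc3)cc2CNc2ccc(C)cc2)cc1`) gives 8380 nM there and compound 3 (`Cc1ccc(-c2nn(-c3ccccc3)cc2CNc2ccc(Br)cc2)cc1`) gives 6760 nM there. Compound 4 (`Cc1ccc(NCc2cn(-c3ccccc3)nc2-c2ccc(Br)cc2)cc1`) is still unmeasured and differs from compound 2 as follows: bromo in place of methyl on an aromatic carbon (bromo in place of methyl on an aromatic carbon, 4-methylphenyl to 4-bromophenyl). Within the data shown here, two measured steps bear on this change. There is a 1.1-fold lower number from compound 2 to compound 3 (0.04 log units; within the scatter) for the same exchange made on the other six-membered aromatic ring, and there is a 1.1-fold lower number from compound 1 to compound 2 (0.06 log units; within the scatter) for methyl in place of methoxy on the ring that changes here. Both steps lie within the scatter, so no shift beyond the scatter is expected in this assay in either direction. The expected step is a 1.1-fold lower number from compound 2 to compound 4 (0.04 log units; within the scatter) and it stays within the scatter. For compound 4 the estimate is 6800 nM with an expected range from 3400 nM to 13000 nM on this read-out.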

Compound 4, half-maximal inhibitory concentration: 5980 nM
Compound 4: middle estimate off by 1.1-fold (0.06 log units), on the high side; measured number inside the range.
By their numbers in this assay, from the lowest: compounds 4, 3, 2 and 1 (each within the scatter of the next).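

In this assay, the first exchange measured with bromo on this ring, 4-methylphenyl to 4-bromophenyl, gives a 1.2-fold lower number from compound 2 to compound 4 (0.09 log units; within the scatter) and so leaves the number level at this aromatic carbon, para to a large group. Among these compounds, the comparison with methoxy at the same place gives a 1.4-fold lower number from compound 1 to compound 4 (0.15 log units; within the scatter), also level, so methoxy, methyl and bromo now all read alike here, whereas the earlier compounds covered only methoxy and methyl at this position. No supporting measurement is available to explain this flat reading.

The compounds shown leave open whether any group at this position can move the number beyond the scatter, for instance an amine, a carboxylic acid or a longer alkoxy chain. They also leave open how the series reads with a bare phenyl here.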